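Solubility notes: trimming the four-membered ring substituent

The compounds below may be only part of what the source reports. "The series", "measured", "known", "first", "only" and "open" are said of these compounds alone.

Measured compounds:
- compound 1, `CC[C@H]1[C@@H](N)CN1c1c(F)cc2c(=O)c(C(=O)O)cn(C3CC3)c2c1F`, 55.9 ug/mL
- compound 2, `CC[C@H]1[C@@H](N)CN1c1cc2c(cc1F)c(=O)c(C(=O)O)cn2C1CC1`, 42.2 ug/mL
- compound 3, `C[C@H]1N(c2cc3c(cc2F)c(=O)c(C(=O)O)cn3C2CC2)C[C@]1(C)N`, 1.3 ug/mL

In a physicochemical assay for solubility, at pH 7.4 (a higher number here means a more soluble compound, a lower number a less soluble compound), compound 1 stands highest of the three numbers. Compound 2 lies nearest, a 1.3-fold lower number from compound 1 to compound 2 (0.12 log units; within the scatter), a difference that does not separate the two. Compound 3 lies furthest, and the step of a 32-fold lower number from compound 2 to compound 3 (1.51 log units; beyond the scatter) is the one large move in the set.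

Compound 4, `C[C@H]1[C@H](N)CN1c1c(F)cc2c(=O)c(C(=O)O)cn(C3CC3)c2c1F`, differs from compound 1 as follows: a group of 6 heavy atoms (4 carbon, 2 nitrogen; one four-membered non-aromatic ring with 1 hetero atom) in place of a group of 7 heavy atoms (5 carbon, 2 nitrogen; one four-membered non-aromatic ring with 1 hetero atom), on an aromatic carbon. The step from compound 2 to compound 3 also exchanges the group on this aromatic carbon, but there one group of 7 heavy atoms replaces another of 7 heavy atoms, so it does not map onto a loss of one carbon. The step from compound 1 to compound 2 concerns fluoro against hydrogen and does not bear on this change. For the measured compounds named here, no measured step therefore matches the change to compound 4 directly. With one carbon fewer in a group of otherwise equal count of donors and acceptors, the expectation in this assay is a step of a 1.3-fold higher number from compound 1 to compound 4 (0.10 log units; within the scatter), that is, nothing beyond the scatter, with any shift leaning upward. Compound 4 is accordingly estimated at 70 ug/mL, with a range from 35 ug/mL to 140 ug/mL.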

Compound 4, solubility: 23.2 ug/mL
Beside the measured number, compound 4's estimate is 3.0-fold (0.48 log units) above it; the measured number lies below the stated range.
By their numbers in this assay, from the lowest: compound 3; then compounds 4, 2 and 1 (each within the scatter of the next, the first and the last beyond it).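

In this assay the smaller group gives a 2.4-fold lower number from compound 1 to compound 4 (0.38 log units; beyond the scatter) on the same core, with the counted donors, acceptors and four-membered ring unchanged. This shows that the number at this aromatic carbon can respond to the loss of one carbon alone, a change that the equal-sized exchange in a 32-fold lower number from compound 2 to compound 3 (1.51 log units; beyond the scatter) could not isolate, and both steps at this position point to a lower number, with no counterexample among the compounds shown. No measurement available here explains the step.

From the compounds shown here alone, whether the group of 6 heavy atoms gives a similar step with hydrogen in place of fluoro, as on the core of compound 2, remains open. Also open, going by these compounds, is what a longer chain such as propyl on the four-membered ring would give.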